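The compounds below may be only part of what the source reports. "The series", "measured", "known", "first", "only" and "open" are said of these compounds alone.

Measured compounds:
compound 1, `CCCCC[Se]c1nc([Se]CCCCC)c2ccccc2n1`; in a functional assay on HTB-54 cells (Homo sapiens) for cytotoxicity, read by MTT assay, with a stated time of 72 h (a lower number here means a stronger inhibitor of growth, a higher number a weaker inhibitor of growth), compound 1 gives > 100000 nM, which is a limit of the assay and not a number.
compound 2, `Nc1nc([SeH])nc2ccccc12`; in this assay compound 2 gives 40 nM.

Going by the values given here, compound 2 therefore holds the only actual number in this assay; the other result recorded is a limit, so nothing can be said about the size of the gap between them beyond the fact that compound 1 lies at the limit of > 100000 nM in this assay, at which 1 of the 2 values shown sits, while compound 2 does not.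

Compound 3, `CCCCC[Se]c1nc(N)c2ccccc2n1`, has not yet been measured. It differs from compound 2 in one place: pentyl in place of hydrogen on a selenium. Compound 2 carries the selenium-bound hydrogen together with the amine; compound 3 keeps the amine but carries the pentyl on the selenium. Because compound 1, which carries pentyl on both seleniums, sits at the limit of > 100000 nM in this assay, at which 1 of the 2 values shown sits, the pentyl is expected to cost activity, and the step of a 130-fold higher number from compound 2 to compound 3 (2.10 log units; beyond the scatter) is expected to be a loss well beyond the scatter, though smaller than a fall to the limit, since compound 3 retains the amine that compound 1 lacks. Compound 3 is therefore expected to give about 5000 nM in this assay, within a range of 400 nM to 60000 nM.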

Compound 3, concentration for 50% growth inhibition: 34600 nM
Compound 3: the middle estimate sits 6.9-fold (0.84 log units) below what was measured, within the range that was stated.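

In this assay, pentyl in place of hydrogen on a selenium, with the amine kept, brings a large loss by itself (an 870-fold higher number from compound 2 to compound 3 (2.94 log units; beyond the scatter)), a change that could not be read alone before, as compound 1 and compound 2 differ in two places. The other new comparison concerns an aromatic carbon of the shared core, where one nitrogen atom takes the place of a group of 6 heavy atoms, and it shows that the amine-bearing compound retains measurable activity (an at least 2.8-fold lower number from compound 1 to compound 3 (0.46 log units; beyond the scatter)). Compound 1 itself stands at a limit of the assay and not at a number, so this second step has only a lower bound: the limit of > 100000 nM in this assay, at which 1 of the 3 values shown sits.

The compounds shown leave open whether the loss belongs to pentyl in particular or would also follow from a methyl, an ethyl or a longer chain on the selenium. They also leave open whether the selenium itself matters, which a sulfur atom at that place, carrying either hydrogen or pentyl, would begin to answer.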